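The compounds below may be only part of what the source reports. "The series", "measured", "known", "first", "only" and "open" are said of these compounds alone.

Three compounds have been measured in a functional assay on A549 cells (Homo sapiens) for inhibition; on this read-out lower numbers stand for stronger inhibition of growth and higher numbers for weaker inhibition of growth:

compound 1, `O=S(=O)(Nc1ccccc1)c1ccc(Br)cc1`, gives 30000 nM;
compound 2, `O=S(=O)(Nc1ccccc1)c1ccc(I)cc1`, gives 23000 nM;
compound 3, `Cc1ccc(NS(=O)(=O)c2ccc(Br)cc2)cc1O`, gives 20000 nM.

Compound 1 and compound 2 share a core and differ in one place only: iodo in place of bromo on an aromatic carbon. That change produced a 1.3-fold lower number from compound 1 to compound 2 (0.12 log units; within the scatter), so on this pair the exchange of one halogen for the other left the read-out essentially where it was. Compound 3 is built on a different core; the difference between the two cores is not broken down here. Its value sits within the scatter of both compound 1 and compound 2, so the three compounds cannot be separated from one another on this read-out.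

Compound 4, `Cc1ccc(NS(=O)(=O)c2ccc(I)cc2)cc1O`, has not yet been measured. It stands to compound 3 exactly as compound 2 stands to compound 1: iodo in place of bromo on an aromatic carbon. This is the same change, at the same place on the ring, that has already been seen once. Going by the values given here, because the one earlier example of this change gave a 1.3-fold lower number from compound 1 to compound 2 (0.12 log units; within the scatter), the step from compound 3 to compound 4 is expected to be similarly small, a 1.3-fold lower number from compound 3 to compound 4 (0.10 log units; within the scatter), with only that single precedent as a guide. Compound 4 is therefore estimated at 16000 nM, expected to lie between 8000 nM and 32000 nM.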

Compound 4, concentration for 50% growth inhibition: 15000 nM
Compound 4: middle estimate off by 1.1-fold (0.03 log units), on the high side; measured number inside the range.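

In this assay, placing iodo where compound 3 carries bromo gave a 1.3-fold lower number from compound 3 to compound 4 (0.12 log units; within the scatter), a step too small to tell apart from the ordinary spread of repeated measurements. Set beside the earlier pair, the same exchange looks alike on the two cores, so in this small set the result on one core was a fair guide to the result on the other: the same change on two cores in this assay, a 1.3-fold lower number (0.12 log units; within the scatter) from compound 1 to compound 2 and a 1.3-fold lower number (0.12 log units; within the scatter) from compound 3 to compound 4, 1.0-fold (0.01 log units) apart, within the scatter of two such steps. Going by these compounds alone, this shows only that the change stays small on both cores; it does not show that iodo truly gives stronger inhibition of growth than bromo, since neither step rises above the scatter, and two cores are too few to say that a third would behave the same way.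

The compounds shown carry only bromo or iodo at this place on the ring, so it remains open whether a different group there, such as an amine, a carboxylic acid or a longer chain, would move the read-out by more than the scatter. From the compounds shown here alone, they also do not separate the methyl from the hydroxyl carried by compound 3 and compound 4, so the part each of these groups plays remains unknown.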